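Amide swap from compound 3 to compound 4

The source may report more compounds than this note shows. Statements on the series, on what has been measured and on what is new or still open speak of the compounds shown alone.

Among the compounds with values here, in a functional assay on MCF7 cells (Homo sapiens) for antiproliferative activity, read by MTT assay, with a stated time of 48 h (a higher number here means a weaker inhibitor, a lower number a stronger inhibitor), compound 3 `CCC(C)C(CO)NC(=O)c1ccc(C(CC)(CC)c2ccc(OCCC(O)(CC)CC)c(C)c2)n1CC` gives 29100 nM, the only exact number so far. Compound 1 `CCn1c(C(=O)NCC#N)ccc1C(CC)(CC)c1ccc(OCCC(O)(CC)CC)c(C)c1` gives > 50000 nM, which is a limit of the assay. Compound 2 `CCn1c(C(=O)Nc2cccc(C(F)(F)F)c2)ccc1C(CC)(CC)c1ccc(OCCC(O)(CC)CC)c(C)c1` gives > 50000 nM, which is also a limit.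

Compound 4 `CCn1c(C(=O)N(C)CCO)ccc1C(CC)(CC)c1ccc(OCCC(O)(CC)CC)c(C)c1` keeps the shared core and alters only the amide: (2-hydroxyethyl)(methyl)amino in place of (1-(hydroxymethyl)-2-methylbutyl)amino on a carbonyl carbon. On the carbonyl carbon, (2-hydroxyethyl)(methyl)amino takes the place of (1-(hydroxymethyl)-2-methylbutyl)amino.

Three measured steps change this same amide nitrogen, and none gives a firm size. The first is an at least 1.7-fold lower number from compound 1 to compound 3 (0.23 log units; that floor lies within the scatter). The second is an at least 1.7-fold lower number from compound 2 to compound 3 (0.23 log units; that floor lies within the scatter). The third is a step that the two limits leave unreadable from compound 1 to compound 2.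

These steps offer no measured basis for a large move in either direction, so no change beyond the scatter is expected in this assay. The estimated step is a 1.4-fold higher number from compound 3 to compound 4 (0.14 log units; within the scatter). For compound 4 the estimated value is 40000 nM, with an expected range of 20000 nM to 75000 nM.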

Compound 4, half-maximal inhibitory concentration: 2870 nM
Compound 4: the middle estimate sits 14-fold (1.14 log units) above what was measured, outside the stated range (below it).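

In this assay, within the data shown here, this amide position gives the first firm step beyond the scatter, a 10-fold lower number from compound 3 to compound 4 (1.01 log units; beyond the scatter), as 5 heavy atoms and 1 hydrogen-bond donor replace 8 heavy atoms and 2 hydrogen-bond donors on the carbonyl carbon. The (2-hydroxyethyl)(methyl)amino group also separates from the other two amides, with an at least 17-fold lower number from compound 2 to compound 4 (1.24 log units; beyond the scatter) and an at least 17-fold lower number from compound 1 to compound 4 (1.24 log units; beyond the scatter). Both of these steps are floors, since compound 1 and compound 2 each carry a limit and not a number: the limit of > 50000 nM in this assay, at which 2 of the 4 values shown sit.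

The compounds shown do not separate the part played by the methyl on the amide nitrogen from that of the 2-hydroxyethyl chain. A (2-hydroxyethyl)amino group, a dimethylamino group or a longer hydroxyalkyl chain at this position would test that split.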